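Benzyloxy in place of methoxy on two chain variants

The source may report more compounds than this note shows. Statements on the series, on what has been measured and on what is new or still open speak of the compounds shown alone.

Compound 1 `CO/N=c1\[nH]cnc2c1[n+](C/C=C(\C)CC/C=C(/C)CCC=C(C)C)cn2C` gives 736 nM in a functional assay on cells (Homo sapiens) for cytotoxicity; a higher number here means a weaker inhibitor, a lower number a stronger inhibitor. Compound 2 `CC(C)=CCC/C(C)=C\CC/C(C)=C/C[n+]1cn(C)c2nc[nH]/c(=N\OCc3ccccc3)c21` gives 6760 nM in this assay. The change between them is phenyl in place of hydrogen on a saturated chain carbon bound to an oxygen and it made a 9.2-fold higher number from compound 1 to compound 2 (0.96 log units; beyond the scatter). Compound 3 `CO/N=c1\[nH]cnc2c1[n+](C/C=C(\C)CCCC(C)CCCC(C)CCCC(C)C)cn2C` carries a different chain; the difference between the cores of compound 1 and compound 3 is not broken down here. In this assay compound 3 gives 3750 nM, a weaker inhibitor than compound 1 and within the scatter of compound 2. Compound 4 `C/C(=C\C[n+]1cn(C)c2nc[nH]/c(=N\OCc3ccccc3)c21)CCCC(C)CCCC(C)CCCC(C)C` is not yet measured; it differs from compound 3 by phenyl in place of hydrogen on a saturated chain carbon bound to an oxygen, the same change already seen between compound 1 and compound 2, at the same place, so that it occurs twice among these four compounds. Among the compounds with values here, a step of a 6.7-fold higher number from compound 3 to compound 4 (0.82 log units; beyond the scatter) is expected, because the one measured instance gave a 9.2-fold higher number from compound 1 to compound 2 (0.96 log units; beyond the scatter); with a single precedent its size is uncertain. Compound 4 is therefore estimated at 25000 nM in this assay, with a range from 8000 nM to 80000 nM.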

Compound 4, half-maximal inhibitory concentration: 7070 nM
Compound 4: the middle estimate sits 3.5-fold (0.55 log units) above what was measured; the measured number lies below the stated range.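

Benzyloxy in place of methoxy does not carry a fixed step from one core to another in this assay. On the second core the change gives a 1.9-fold higher number from compound 3 to compound 4 (0.28 log units; within the scatter), and the two instances do not agree: the same change on two cores in this assay, a 9.2-fold higher number (0.96 log units; beyond the scatter) from compound 1 to compound 2 and a 1.9-fold higher number (0.28 log units; within the scatter) from compound 3 to compound 4, 4.9-fold (0.69 log units) apart, beyond the scatter of two such steps

These four compounds therefore show that the size of this step depends on the core carrying it, so a step read on one core is a poor guide to the step on the other. Within the data shown here, they do not show which part of the two chains accounts for the gap, and with only two pairs they give no rule for a third core.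

Still open, going by these compounds, is whether an intermediate group on the oxygen, such as ethoxy, or a ring-substituted one, such as fluorobenzyloxy, would follow either pair. Also open, on these data alone, is how the same change would read on a shorter chain, such as a single prenyl unit, or on a longer one.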